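A few compounds are considered here, and "the series" means these few. Any claim that something is new, unique, unknown or untested is made for them only; others in the source may bear on it.

Measured so far in a physicochemical assay for lipophilicity, read by HPLC, measured as chromatographic lipophilicity, at pH 7.4; a higher number here means a more lipophilic compound, a lower number a more polar compound:
compound 1 `O=C(C1CCCCC1)N1CCC(C(=O)N2N=CCC2c2ccccc2)CC1` gives 5.4
compound 2 `CC(C)(C)C(=O)N1N=CCC1c1cocn1` gives 3
compound 3 `CC(C)(C)C(=O)N1N=CCC1c1cccc(Cl)c1` gives 6.6

Compound 2 stands lowest of the three numbers in this assay; compound 1 lies nearest to it and compound 3 furthest, both beyond the scatter. Within the data shown here, no pair of the measured compounds differs in one place only, so no single step is known from them. Compound 4 `CC(C)(C)C(=O)N1N=CCC1c1cc[nH]n1` is not yet measured. It differs from compound 2 as follows: 1H-pyrazol-3-yl in place of 1,3-oxazol-4-yl on a saturated ring carbon. One five-membered aromatic ring with 2 hetero atoms replaces another of the same size, now with 1 hydrogen-bond donor. The step from compound 2 to compound 4 in this assay is expected to be small, in either direction, and not beyond the scatter. Compound 4 is thus estimated at 3.1, ranging from 2.5 to 3.7. The expected step is a number 0.10 log units higher from compound 2 to compound 4 (within the scatter).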

Compound 4, distribution coefficient: 2.7
Compound 4: middle estimate off by 0.40 log units, on the high side; low and high end bracket the measured number.
By their numbers in this assay, from the lowest: compounds 4 and 2 (each within the scatter of the next); then compound 1; then compound 3.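

In this assay, among these compounds, 1H-pyrazol-3-yl in place of 1,3-oxazol-4-yl on a saturated ring carbon gives a number 0.30 log units lower from compound 2 to compound 4 (within the scatter) and is the first step that can be read at a single place. At this position, one five-membered aromatic ring with 2 hetero atoms can thus replace another, now with 1 hydrogen-bond donor, without a change beyond the scatter. Going by these compounds, whether an amine or a carboxylic acid on this ring carbon would stay as close to compound 2 remains open. No evidence on hand bears on this step.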